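The compounds below may be only part of what the source reports. "The series", "measured", "known", "first", "only" and "open" are said of these compounds alone.

In a functional assay on a cell-free system (Platelet, plasma, Homo sapiens) for inhibition (a lower number here means a stronger inhibitor, a higher number a weaker inhibitor), compound 1 `O=C(O)CN1Cc2ccc(NC(=O)c3ccc4c(c3)CNCC4)cc2C1=O` gives 120000 nM, compound 3 `CC(CC(=O)O)N1Cc2ccc(NC(=O)c3ccc(N4CCNCC4)cc3)cc2C1=O` gives 3740 nM, and compound 2 `CC(CC(=O)O)N1Cc2ccc(NC(=O)CCCC3CCNCC3)cc2C1=O` gives 5400 nM. Compound 2 thus lies within the scatter of compound 3, while compound 1 reads higher by a margin well beyond the scatter. Compound 4 `O=C(O)CCN1Cc2ccc(NC(=O)CCCC3CCNCC3)cc2C1=O`, not yet measured, differs from compound 2 in one place: hydrogen in place of methyl on a saturated chain carbon bound to an amide-type nitrogen in a ring and a saturated chain carbon. This puts hydrogen in place of methyl on a saturated chain carbon bound to an amide-type nitrogen in a ring and a saturated chain carbon, turning 1-(carboxymethyl)ethyl into 2-carboxyethyl. Among the measured compounds shown here, no measured pair shows this change alone, so nothing beyond the scatter is expected in this assay, and the estimated step is a 1.1-fold lower number from compound 2 to compound 4 (0.03 log units; within the scatter). The value expected for compound 4 is 5000 nM, within a range of 1200 nM to 20000 nM.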

Compound 4, half-maximal inhibitory concentration: 5900 nM
Estimate against measurement, compound 4: 1.2-fold (0.07 log units) below; the range from low to high includes it.
By their numbers in this assay, from the lowest: compounds 3, 2 and 4 (each within the scatter of the next); then compound 1.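

In this assay, among the compounds shown here, the change from 1-(carboxymethyl)ethyl to 2-carboxyethyl gives a 1.1-fold higher number from compound 2 to compound 4 (0.04 log units; within the scatter) and so offers the first direct reading at this position. With the shared core and side chain held constant, the methyl on this saturated chain carbon is not required to keep this level of inhibition. No supporting data bear on the reason for this result.

From the compounds shown here alone, whether a longer chain carrying the carboxylic acid, or a phenyl group on this same carbon, would stay within the scatter of compound 2 remains open. So does whether hydrogen in place of methyl would read the same on compound 3.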